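A few compounds are considered here, and "the series" means these few. Any claim that something is new, unique, unknown or untested is made for them only; others in the source may bear on it.

Measured to date
Compound 1 `CCCCCCCCn1cc(/C=C/C(=O)c2ccc(N)cc2)nn1` gives 26900 nM in a functional assay on A549 cells (Homo sapiens) for inhibition, read by MTT assay; on this read-out lower numbers stand for stronger inhibition and higher numbers for weaker inhibition.
Compound 2 `CCCCCCCCn1cc(/C=C/C(=O)c2ccc(NC(=O)CN3CCN(C(=O)OC(C)(C)C)CC3)cc2)nn1` gives 43300 nM in this assay.

Compound 1 and compound 2 lie within the usual scatter of each other on this read-out, so neither stands apart; the two numbers together mark where the series sits at present.

Compound 3 `CCCCCCCCn1cc(/C=C/C(=O)c2ccc(NC(=O)CBr)cc2)nn1` has not been measured. Against compound 1 the change is (bromomethyl)carbonyl in place of hydrogen on a nitrogen on an aromatic ring, a (bromomethyl)carbonyl in place of hydrogen on a nitrogen on an aromatic ring. Going by the values given here, no step between measured compounds covers this change, and the only other substitution on the same nitrogen, in compound 2, left the number within the scatter of compound 1. The step of a 2.7-fold lower number from compound 1 to compound 3 (0.43 log units; beyond the scatter) is therefore expected to be modest, toward a lower number, and may not clear the scatter. Compound 3 is estimated at 10000 nM, with a plausible range from 2500 nM to 40000 nM.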

Compound 3, half-maximal inhibitory concentration: 11600 nM
Compound 3: the middle estimate sits 1.2-fold (0.06 log units) below what was measured; the measured number falls inside the stated range.
By their numbers in this assay, from the lowest: compound 3; then compounds 1 and 2 (each within the scatter of the next).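

In this assay, (bromomethyl)carbonyl in place of hydrogen on a nitrogen on an aromatic ring gives a 2.3-fold lower number from compound 1 to compound 3 (0.37 log units; beyond the scatter), a modest step but one that lies beyond the scatter. Compound 2, substituted on the same nitrogen, stays within the scatter of compound 1, so substitution at this nitrogen does not move the number in every case, and the outcome differs with the group attached. No independent measurement bears on why the number moves with this change.

Open, on these data alone, is whether the step depends on the bromine: acetyl or (chloromethyl)carbonyl on the same nitrogen would test this. As far as these compounds go, all three compounds share the same chain on the core, so the response to a shorter chain also remains unknown.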